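The compounds below may be only part of what the source reports. "The series", "measured", "known", "first", "only" and "open" are said of these compounds alone.

Measured compounds in an assay on cells (Kidney epithelial cell, kidney) for inhibition of sodium/hydrogen exchanger 3 (Homo sapiens), read by fluorescence, in the presence of a further agent that is not named here; on this read-out higher numbers stand for weaker inhibition and lower numbers for stronger inhibition:
compound 1 `CN1Cc2c(Cl)cc(Cl)cc2C(c2cccc(S(=O)(=O)NCCOCCOCCOCCNC(=O)C(O)C(O)NCCOCCOCCOCCNS(=O)(=O)c3cccc(C4CN(C)Cc5c(Cl)cc(Cl)cc54)c3)c2)C1` gives 79.4 nM
compound 2 `CN1Cc2c(Cl)cc(Cl)cc2C(c2cccc(S(=O)(=O)NCCOCCNC(=O)C(O)C(O)NCCOCCNS(=O)(=O)c3cccc(C4CN(C)Cc5c(Cl)cc(Cl)cc54)c3)c2)C1` gives 316 nM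
compound 3 `CN1Cc2c(Cl)cc(Cl)cc2C(c2ccc(S(=O)(=O)NCCOCCOCCOCCNC(=O)C(O)C(O)NCCOCCOCCOCCNS(=O)(=O)c3ccc(C4CN(C)Cc5c(Cl)cc(Cl)cc54)cc3)cc2)C1` gives 158 nM

Compound 1 has the lowest number of the three in this assay. Its gap to compound 3 is within the scatter, so the two cannot be ranked against each other; its gap to compound 2 is beyond the scatter, and on these numbers compound 1 inhibits more strongly than compound 2. Going by the values given here, no single-point step between measured compounds is available, so nothing in this set shows how a stereochemical definition alone moves the number.

Compound 4 `CN1Cc2c(Cl)cc(Cl)cc2[C@@H](c2cccc(S(=O)(=O)NCCOCCOCCOCCNC(=O)C(O)C(O)NCCOCCOCCOCCNS(=O)(=O)c3cccc([C@H]4CN(C)Cc5c(Cl)cc(Cl)cc54)c3)c2)C1` is the next compound to be measured. It differs from compound 1 as follows: the two compounds have the same atoms and bonds; at least one stereo element is drawn with a configuration in one of them and without one in the other: 2 of 4 stereo elements differ; a stereocentre at a saturated ring carbon is drawn without a configuration in compound 1 and R in compound 4; a stereocentre at a saturated ring carbon is drawn without a configuration in compound 1 and R in compound 4. The atoms and bonds are unchanged; only the drawn configuration at two saturated ring carbons is new.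

Because compound 1 is drawn without configuration and gives 79.4 nM, compound 4 is expected to land close to it, with a step of a 1.6-fold lower number from compound 1 to compound 4 (0.20 log units; within the scatter) in this assay, either none beyond the scatter or a modest move toward a lower number. For compound 4 the estimate in this assay is 50 nM, within a range of 15 nM to 200 nM.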

Compound 4, half-maximal inhibitory concentration: > 31600 nM
Compound 4: a limit, no number; the forecaster's own chance of this, stated with the estimate: 3%; middle value at least 630-fold (2.80 log units) away from the limit.
By their numbers in this assay, from the lowest: compounds 1, 3 and 2 (each within the scatter of the next, the first and the last beyond it). At a limit, above all of these: compound 4.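

In this assay, compound 4 gives > 31600 nM, which is a limit of the assay and not a number. Going by these compounds alone, with atoms and bonds unchanged, an at least 390-fold higher number from compound 1 to compound 4 (2.59 log units; beyond the scatter) is the only step in this set that reads drawn configuration alone, and it shows that inhibition depends strongly on the two saturated ring carbons, with the R configuration at both not retaining the inhibition seen for the drawing without configuration. The earlier compounds varied only in chain length and in the attachment of the sulfonamide to the aryl ring, and they could not show this dependence; the comparison rests on a single difference between the pair: the fact that one of compounds 1 and 4 is drawn with a defined configuration and the other without, at the place where they differ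

Whether the S configuration at both ring carbons, or a mixed R and S pairing, accounts for the inhibition of compound 1 remains open. Also open, on these data alone, is whether configuration at these carbons has the same weight with a longer chain or with a carboxylic acid on the chain.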